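The source may report more compounds than this note shows. Statements on the series, on what has been measured and on what is new or still open speak of the compounds shown alone.

Compound 2 `CCCCCCCCOc1ccc(NC(=O)Oc2ccccc2)cc1` gives 5.4 nM in an assay on H4 cells for inhibition of Fatty-acid amide hydrolase 1 (Homo sapiens) (on this read-out higher numbers stand for weaker inhibition and lower numbers for stronger inhibition), and compound 1 `CCCCCCCOc1ccc(NC(=O)Oc2ccccc2)cc1` gives 8.6 nM; the step of a 1.6-fold lower number from compound 1 to compound 2 (0.20 log units; within the scatter) keeps the two within the scatter of each other, so neither can be called stronger. Compound 3 `CCCCCCCCCCCCOc1ccc(NC(=O)Oc2ccccc2)cc1` differs from compound 2 by butyl in place of hydrogen on a saturated chain carbon, eight bonds along the chain from an oxygen on an aromatic ring. Among the compounds with values here, only the step from compound 1 to compound 2 bears on this, a lengthening of the same chain, and it stayed within the scatter. A longer extension in the same direction is expected to give at most a modest step of a 1.5-fold lower number from compound 2 to compound 3 (0.19 log units; within the scatter) toward a lower number. Compound 3 is therefore expected to give about 3.5 nM, within a range from 1 nM to 12 nM.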

Compound 3, half-maximal inhibitory concentration: 1.8 nM
Compound 3: the middle estimate sits 1.9-fold (0.29 log units) above what was measured; measured number inside the range.
By their numbers in this assay, from the lowest: compound 3; then compounds 2 and 1 (each within the scatter of the next).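

Butyl in place of hydrogen on a saturated chain carbon, eight bonds along the chain from an oxygen on an aromatic ring, gives a 3.0-fold lower number from compound 2 to compound 3 (0.48 log units; beyond the scatter) in this assay, so lengthening this chain can move the number beyond the scatter, which the earlier step did not show. Measured against the shortest chain here, the lengthening gives a 4.8-fold lower number from compound 1 to compound 3 (0.68 log units; beyond the scatter), and compound 3, with the longest chain, stands clear of both others. Nothing available explains this gain. Still open, as far as these compounds go, is whether a longer chain would lower the number further or raise it again, and how an amine or a carboxylic acid on this chain would read.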